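A few compounds are considered here, and "the series" means these few. Any claim that something is new, unique, unknown or untested is made for them only; others in the source may bear on it.

Three compounds that share a large common portion were tested in an ADME assay on Vero cells (Chlorocebus sabaeus) for cytotoxicity; a higher number here means that more compound is tolerated, a lower number that less compound is tolerated. Compound 1 `O=C1C(=O)N(Cc2cn(CC(=O)N3CCN(c4cc5c(cc4F)c(=O)c(C(=O)O)cn5C4CC4)CC3)nn2)c2ccc(F)cc21` gives 32 ug/mL in this assay. Compound 3 `Cc1ccc2c(c1)C(=O)C(=O)N2Cc1cn(CC(=O)N2CCN(c3cc4c(cc3F)c(=O)c(C(=O)O)cn4C3CC3)CC2)nn1` gives 16 ug/mL. Compound 2 `CO/N=C1/C(=O)N(Cc2cn(CC(=O)N3CCN(c4cc5c(cc4F)c(=O)c(C(=O)O)cn5C4CC4)CC3)nn2)c2ccc(C)cc21` gives 8 ug/mL, the lowest of the three numbers; the gap to compound 3 lies within the usual scatter, while the gap to compound 1 lies beyond it. Compound 3 and compound 1 differ in one place, (fluoro in place of methyl on an aromatic carbon), and this change made a step of a 2.0-fold higher number from compound 3 to compound 1 (0.30 log units; within the scatter). How the core of compound 2 differs from the core of compound 3 is not broken down here. Compound 4 `CO/N=C1/C(=O)N(Cc2cn(CC(=O)N3CCN(c4cc5c(cc4F)c(=O)c(C(=O)O)cn5C4CC4)CC3)nn2)c2ccc(F)cc21` has not yet been measured; it stands to compound 2 as compound 1 stands to compound 3, through (fluoro in place of methyl on an aromatic carbon), and the two places are described in the same words. Among the compounds with values here, the step expected in this assay is a 1.5-fold higher number from compound 2 to compound 4 (0.18 log units; within the scatter), resting on the single earlier step of a 2.0-fold higher number from compound 3 to compound 1 (0.30 log units; within the scatter) and on compound 2 at 8 ug/mL. For compound 4 the estimate is therefore 12 ug/mL, with a likely range from 6 ug/mL to 24 ug/mL.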

Compound 4, half-maximal cytotoxic concentration: 64 ug/mL
Compound 4: the middle estimate sits 5.3-fold (0.73 log units) below what was measured; the whole stated range lies below it.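

In this assay, fluoro in place of methyl on an aromatic carbon gives an 8.0-fold higher number from compound 2 to compound 4 (0.90 log units; beyond the scatter), a clear rise on this core. The same change gave a 2.0-fold higher number from compound 3 to compound 1 (0.30 log units; within the scatter), so the size of the step did not carry over from one core to the other: the same change on two cores in this assay, a 2.0-fold higher number (0.30 log units; within the scatter) from compound 3 to compound 1 and an 8.0-fold higher number (0.90 log units; beyond the scatter) from compound 2 to compound 4, 4.0-fold (0.60 log units) apart, beyond the scatter of two such steps. A step measured on one core is therefore a poor guide to its size on the other in this series, but two pairs of compounds cannot show which feature of the cores sets the size, and they establish no rule for a third core.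

The compounds shown leave open whether chloro or an amine at this place would behave more like fluoro or like methyl on each of the two cores. Within the data shown here, they also leave open how the swap from methyl to fluoro would read on any other core, and whether a large step like the one to compound 4 would appear there.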